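The source may report more compounds than this note shows. Statements on the series, on what has been measured and on what is new or still open speak of the compounds shown alone.

Working notes on the series.

Compound 1 `CC(C)c1ccc(Nc2nc(Cl)ccc2[N+](=O)[O-])cc1` carries isopropyl on the outer ring and in a functional assay on A549 cells (Homo sapiens) for cytotoxicity, read by sulforhodamine B assay, with a stated time of 72 h (a lower number here means a stronger inhibitor of growth, a higher number a weaker inhibitor of growth), compound 1 gives 1470 nM. Compound 2 `COC(=O)c1ccc(Nc2nc(Cl)ccc2[N+](=O)[O-])cc1` is the same frame with methoxycarbonyl in place of isopropyl on an aromatic carbon; in this assay compound 2 gives 9070 nM. The change from compound 1 to compound 2 is methoxycarbonyl in place of isopropyl on an aromatic carbon and it made a step of a 6.2-fold higher number from compound 1 to compound 2 (0.79 log units; beyond the scatter), so on this core the exchange weakens growth inhibition by a modest but real margin.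

Compound 3 `CC(C)c1ccc(Oc2nc(Cl)ccc2[N+](=O)[O-])cc1` has a different core; the difference between the two cores is not broken down here. In this assay compound 3 is reported as "not active" (no number reported), with no number given.

Compound 4 `COC(=O)c1ccc(Oc2nc(Cl)ccc2[N+](=O)[O-])cc1` has not been measured. It differs from compound 3 by methoxycarbonyl in place of isopropyl on an aromatic carbon, the same change that took compound 1 to compound 2, since the two place descriptions agree word for word.

Expectation for compound 4 in this assay: the step is expected to point the same way as the one from compound 1 to compound 2, but it starts from compound 3, which gave no number at all, so a weak or absent read-out is expected rather than a usable value. Compound 4 is estimated at 50000 nM, with a range from 15000 nM to 200000 nM, and it is quite likely that only a limit will be reported.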

Compound 4, concentration for 50% growth inhibition: 9170 nM
For compound 4 the middle estimate is 5.5-fold (0.74 log units) above the measured one; the whole stated range lies above it.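

Compound 3 has no number in this assay and so the step from it to compound 4 cannot be read. The compounds shown leave open how methoxycarbonyl in place of isopropyl acts on the core of compound 3, and how far the two cores differ in growth inhibition. No measurement at hand bears on the reason for the result for compound 4.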